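The source may report more compounds than this note shows. Statements on the series, on what has been measured and on what is new or still open speak of the compounds shown alone.

In an assay on isolated protein for binding affinity to melanin-concentrating hormone receptor 1 (Homo sapiens) (on this read-out higher numbers stand for weaker inhibition and lower numbers for stronger inhibition), compound 1 `N#Cc1cccc([C@]23CC[C@@H](N(CN4CCCCC4)c4nc5cc(Cl)c(Cl)cc5[nH]4)C[C@H]2C3)c1` gives 2.5 nM, compound 2 `CN1CCN(CCCN(c2nc3cc(Cl)c(Cl)cc3[nH]2)[C@@H]2CC[C@]3(c4cccc(C=O)c4)C[C@@H]3C2)CC1` gives 13.7 nM, and compound 3 `CN1CCN(CCCN(c2nc3cc(F)c(F)cc3[nH]2)[C@@H]2CC[C@]3(c4cccc(C=O)c4)C[C@@H]3C2)CC1` gives 16.3 nM, which stands at the top of the three numbers, within the scatter of compound 2 but beyond it from compound 1. Within the data shown here, the one measured single change, a 1.2-fold higher number from compound 2 to compound 3 (0.08 log units; within the scatter), lies within the scatter. Compound 4 `CN1CCN(CCCN(c2nc3cc(F)c(F)cc3[nH]2)[C@@H]2CC[C@]3(c4cccc(CN5CC[C@H](O)C5)c4)C[C@@H]3C2)CC1` differs from compound 3 by (3-hydroxypyrrolidin-1-yl)methyl in place of formyl on an aromatic carbon. Among the measured compounds shown here, no measured step touches this part of the molecule, so the size of this step cannot be read from the earlier pairs, and the value of compound 3 is the only guide. The change from compound 3 to compound 4 is therefore expected to be a 1.4-fold lower number from compound 3 to compound 4 (0.13 log units; within the scatter), with no firm direction. Compound 4 is estimated at 12 nM in this assay, between 4 nM and 40 nM.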

Compound 4, inhibition constant: 441 nM
For compound 4 the middle estimate is 37-fold (1.57 log units) below the measured one; the measured number lies above the stated range.
By their numbers in this assay, from the lowest: compound 1; then compounds 2 and 3 (each within the scatter of the next); then compound 4.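

Among these compounds, this is the only measured change at this aromatic carbon, and in this assay it is large: a 27-fold higher number from compound 3 to compound 4 (1.43 log units; beyond the scatter). The position therefore responds strongly to what it carries, which the earlier step on the benzimidazole halogens, within the scatter, could not show. Nothing measured here explains the step. The compounds shown leave open whether the ring, the hydroxyl or the defined stereocentre of the (3-hydroxypyrrolidin-1-yl)methyl group goes with the weaker number. A plain hydroxymethyl or pyrrolidin-1-ylmethyl group at this carbon would separate these parts.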